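A Pyridyl Swap on the Shared Core: Cytotoxicity Outlook

A few compounds are considered here, and "the series" means these few. Any claim that something is new, unique, unknown or untested is made for them only; others in the source may bear on it.

Compound 1 `Cc1ccccc1C(=O)Nc1nc(-c2ccccn2)cs1` was examined in an ADME assay on Vero cells (Chlorocebus sabaeus) for cytotoxicity, read by MTT assay, with a stated time of 72 h (on this read-out higher numbers stand for an effect only at larger amounts of compound and lower numbers for an effect already at smaller amounts), where compound 1 gives 6300 nM. Compound 2 `O=C(Nc1nc(-c2ccccn2)cs1)c1cccc(F)c1F` in this assay gives 7200 nM, a number within the scatter of that of compound 1, so the two cannot be told apart. Compound 3 `O=C(Nc1nc(-c2ccccn2)cs1)c1cccnc1Cl` has not yet been measured. It differs from compound 1 in one place (2-chloropyridin-3-yl in place of 2-methylphenyl on a carbonyl carbon). Going by the values given here, no measured pair shows what such a change does on this read-out, so no step beyond the scatter is expected in this assay in either direction. Compound 3 is therefore expected to give about 6500 nM, plausibly between 3000 nM and 14000 nM. The expected step is a 1.0-fold higher number from compound 1 to compound 3 (0.01 log units; within the scatter).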

Compound 3, half-maximal effective concentration: 1900 nM
The estimate for compound 3 lay 3.4-fold (0.53 log units) above the measured number, outside the stated range (below it).
By their numbers in this assay, from the lowest: compound 3; then compounds 1 and 2 (each within the scatter of the next).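

In this assay, the group on the carbonyl carbon proved able to shift the number beyond the scatter: 2-chloropyridin-3-yl in place of 2-methylphenyl gave a 3.3-fold lower number from compound 1 to compound 3 (0.52 log units; beyond the scatter), so cytotoxicity appeared at smaller amounts of compound. This single change therefore does not leave the read-out untouched. Nothing available accounts for this step.

The compounds shown do not separate the contribution of the ring nitrogen from that of the chlorine. From the compounds shown here alone, it remains open how a 2-chlorophenyl or an unsubstituted pyridin-3-yl group at this place would read.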